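Triazolyl aryl swap on the hydroxychalcone: cytotoxicity notes

The source may report more compounds than this note shows. Statements on the series, on what has been measured and on what is new or still open speak of the compounds shown alone.

Compound 1 `COc1cc(OC)c2c(=O)cc(-c3ccc(OCc4cn(-c5ccc(F)cc5F)nn4)c(OC)c3)oc2c1`. In an ADME assay on Huh-7 cells (Homo sapiens) for cytotoxicity, read by MTT assay, with a stated time of 72 h (on this read-out lower numbers stand for higher toxicity in this test and higher numbers for lower toxicity in this test), compound 1 gives > 100 ug/mL, a limit of the assay.
Compound 2 `COc1cc(O)c(C(=O)/C=C/c2ccc(OCc3cn(-c4ccccc4Cl)nn3)c(OC)c2)c(OC)c1`. In this assay compound 2 gives > 100 ug/mL, again a limit.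
Compound 3 `COc1cc(O)c(C(=O)/C=C/c2ccc(OCc3cn(-c4ccccc4Cl)nn3)c(OCc3cn(-c4ccccc4Cl)nn3)c2)c(OC)c1`. In this assay compound 3 gives > 100 ug/mL, a limit as well.

Compound 2 therefore stands only at a limit, with no number to place it. Among the compounds with values here, the one step within the set, a step that the two limits leave unreadable from compound 2 to compound 3, cannot be sized; the only evidence is the limit of > 100 ug/mL in this assay, at which 3 of the 3 values shown sit. Compound 4 `COc1cc(O)c(C(=O)/C=C/c2ccc(OCc3cn(-c4ccc(F)cc4F)nn3)c(OC)c2)c(OC)c1` differs from compound 2 by 2,4-difluorophenyl in place of 2-chlorophenyl on an aromatic nitrogen. Within the data shown here, no measured step covers this aryl swap, so no direction is read from the data. Compound 4 is expected to remain at the limit, estimated at 150 ug/mL (range 80 ug/mL to 300 ug/mL), the step that the limit leaves unreadable from compound 2 to compound 4 expected to be none beyond the scatter.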

Compound 4, half-maximal cytotoxic concentration: > 100 ug/mL
Compound 4 was reported as a limit; the forecaster's own chance of this, stated with the estimate: 80%; the middle value lies beyond the limit too.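

No step can be read from compound 2 to compound 4, since both stand only at a limit: the limit of > 100 ug/mL in this assay, at which 4 of the 4 values shown sit.

The compounds shown leave open whether swapping 2-chlorophenyl for 2,4-difluorophenyl on the triazole-bound aromatic nitrogen changes cytotoxicity at all.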